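The source may report more compounds than this note shows. Statements on the series, on what has been measured and on what is new or still open speak of the compounds shown alone.

Measured compounds in an assay on HeLa cells for inhibition of Indoleamine 2,3-dioxygenase 1 (Homo sapiens); a higher number here means a weaker inhibitor, a lower number a stronger inhibitor:
compound 1 `O=C(Nc1ccc(F)cc1)C1(c2ccc3c(n2)CCN3c2ccccn2)CCC1` gives 10.9 nM
compound 2 `Cc1nccc(N2CCc3nc(C4(NC(=O)c5ccc(Cl)cc5)CCC4)ccc32)n1` gives 46 nM
compound 3 `Cc1nccc(N2CCc3nc(C4(C(=O)Nc5ccc(Cl)cc5)CCC4)ccc32)n1` gives 12.5 nM

Compound 3 stands second of the three numbers. Its nearest neighbour is compound 1, within the scatter; the gap to compound 2 is beyond the scatter. Within the data shown here, the only step between measured compounds that differ in one place is a 3.7-fold lower number from compound 2 to compound 3 (0.57 log units; beyond the scatter), a modest step that concerns the amide attachment and not the ring on the nitrogen.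

Compound 4 `O=C(Nc1ccc(Cl)cc1)C1(c2ccc3c(n2)CCN3c2ccccn2)CCC1` is not yet measured. It differs from compound 3 in one place: pyridin-2-yl in place of 2-methylpyrimidin-4-yl on a nitrogen on an aromatic ring in a ring. Among the measured compounds shown here, no measured pair isolates this change. Compound 1 carries the pyridin-2-yl group together with a 4-fluorophenyl amide, compound 3 the 2-methylpyrimidin-4-yl group together with a 4-chlorophenyl amide, and their two values lie within the scatter of each other; this is the only indication available, and it mixes two differences. There is no ground to expect a step beyond the scatter in this assay in either direction. Compound 4 is therefore expected to lie close to compound 3, with a 1.1-fold lower number from compound 3 to compound 4 (0.06 log units; within the scatter) as the implied step. The estimate for compound 4 in this assay is 11 nM, expected to fall between 4 nM and 30 nM.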

Compound 4, half-maximal inhibitory concentration: 2.3 nM
The estimate for compound 4 lay 4.8-fold (0.68 log units) above the measured number, and the stated range ends above it.
By their numbers in this assay, from the lowest: compound 4; then compounds 1 and 3 (each within the scatter of the next); then compound 2.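

In this assay, the group on the nitrogen of the five-membered non-aromatic ring now has a read of its own: pyridin-2-yl in place of 2-methylpyrimidin-4-yl gives a 5.4-fold lower number from compound 3 to compound 4 (0.74 log units; beyond the scatter) with the 4-chlorophenyl amide held constant, so this position is not silent in the series. The halogen also counts, since chloro in place of fluoro on an aromatic carbon gives a 4.7-fold lower number from compound 1 to compound 4 (0.68 log units; beyond the scatter) with pyridin-2-yl held constant, and the two differences that were mixed before are thus separated into two steps beyond the scatter, each resting on a single pair. No measurement on hand accounts for either step.

The change at the nitrogen swaps the ring and removes the methyl together, so a plain pyrimidin-4-yl or a 2-methylpyridin-4-yl group would be needed to tell which part carries the step. Also open, as far as these compounds go, are whether bromo or trifluoromethyl on that aromatic carbon extends the halogen step, and whether pyridin-2-yl gives a similar step on the reversed amide of compound 2.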